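The source may hold more compounds than are shown below. What is called first, only, known or untested is meant among the compounds shown, and "the series" means these compounds.

Compound 2, `Cc1ccccc1-n1nc(C)c2c1NC(=O)[C@H](C)S[C@@H]2c1ccc(-c2cc3ccccc3o2)cc1`, gives 1500 nM in an assay on isolated protein for agonist activity at Bile acid receptor (Homo sapiens), read by AlphaScreen, with a stated time of 30 min; a lower number here means that less compound is needed, a higher number that more compound is needed for the effect. Among the three compounds measured so far its number lies between those of the other two, but neither gap reaches beyond the scatter: compound 1, `CCc1ccccc1-n1nc(C)c2c1NC(=O)[C@H](C)S[C@@H]2c1ccc(Oc2ccccc2)cc1`, gives 1100 nM in this assay, and compound 3, `Cc1nn(-c2ccccc2C(F)(F)F)c2c1C(c1ccc(Oc3ccccc3)cc1)SC(C)C(=O)N2`, gives 2000 nM. All three therefore read as roughly the same level of potency, with no ordering that the data can support.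

Compound 4, `Cc1ccccc1-n1nc(C)c2c1NC(=O)[C@H](C)S[C@@H]2c1ccc(-c2ccccc2)cc1`, differs from compound 2 in one place: phenyl in place of 1-benzofuran-2-yl on an aromatic carbon. The 1-benzofuran-2-yl group of compound 2 is replaced by a phenyl, with the rest of the shared core unchanged. Among the compounds with values here, no measured pair among compounds 1 to 3 isolates this change, so its effect can only be guessed from how little the three measured numbers move despite their different substituents on that aromatic carbon.

On that basis no step beyond the scatter is expected in this assay for compound 4, perhaps a modest rise in the number at most. The estimate for compound 4 is 2200 nM, with a range from 700 nM to 7000 nM, which means an expected step of a 1.5-fold higher number from compound 2 to compound 4 (0.17 log units; within the scatter).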

Compound 4, half-maximal effective concentration: 990 nM
For compound 4 the middle estimate is 2.2-fold (0.35 log units) above the measured one; the measured number falls inside the stated range.
By their numbers in this assay, from the lowest: compounds 4, 1, 2 and 3 (each within the scatter of the next, the first and the last beyond it).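

Within the data shown here, compound 2 and compound 4 form the first pair that isolates this position. In this assay, phenyl in place of 1-benzofuran-2-yl on an aromatic carbon, para to a large group, gives a 1.5-fold lower number from compound 2 to compound 4 (0.18 log units; within the scatter), a step that stays within the scatter. The five-membered aromatic ring, with its hetero atom and the one hydrogen-bond acceptor counted for 1-benzofuran-2-yl, can therefore be absent from this position without a readable change in this assay, although nothing available explains that outcome.

The compounds shown leave open whether this tolerance extends beyond these two aromatic groups, for example to a much smaller group such as a methyl or a chlorine atom on that same aromatic carbon. They also leave open whether a carboxylic acid or an amine carried on the phenyl of compound 4 would produce a step beyond the scatter in this assay.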